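Trading a Phenyl for a Methyl on the Carbonyl

The source may hold more compounds than are shown below. What is called first, only, known or untested is meant among the compounds shown, and "the series" means these compounds.

In a functional assay on SF-295 cells (Homo sapiens) for inhibition, read by sulforhodamine B assay, with a stated time of 48 h (a higher number here means a weaker inhibitor of growth, a lower number a stronger inhibitor of growth), compound 1 `N#C/C(=C\c1c(-c2ccccc2)[nH]c2ccccc12)C(=O)c1ccccc1` gives 3000 nM and compound 2 `O=C(/C(=C\c1c(-c2ccccc2)[nH]c2ccccc12)S(=O)(=O)c1ccccc1)c1ccccc1` gives 3500 nM. Compound 2 has the higher of the two numbers, yet its gap to compound 1 lies within the usual scatter, so the two cannot be told apart. Compound 3 `CC(=O)/C(=C\c1c(-c2ccccc2)[nH]c2ccccc12)S(=O)(=O)c1ccccc1` keeps the core of compound 2 and carries one change: methyl in place of phenyl on a carbonyl carbon. Among the measured compounds shown here, no measured pair shows this change, so nothing here tells how large its effect is. The step from compound 2 to compound 3 is expected to be a 1.3-fold higher number from compound 2 to compound 3 (0.11 log units; within the scatter), a modest change and possibly none beyond the scatter. Compound 3 is estimated at 4500 nM, with a range from 1500 nM to 14000 nM.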

Compound 3, concentration for 50% growth inhibition: 2400 nM
The estimate for compound 3 lay 1.9-fold (0.27 log units) above the measured number, and the stated range covers the measured number.
By their numbers in this assay, from the lowest: compounds 3, 1 and 2 (each within the scatter of the next).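

Cutting benzoyl down to acetyl, with methyl in place of phenyl on a carbonyl carbon, gives a 1.5-fold lower number from compound 2 to compound 3 (0.16 log units; within the scatter) in this assay, and this step lies within the scatter. In this pair, then, the phenyl on the carbonyl can go without a readable change in growth inhibition. On these data alone, whether a longer chain such as ethyl, or an amine turning the carbonyl into an amide, would also leave the number within the scatter stays open. So does whether the same change would read alike on compound 1, which carries a nitrile. No evidence shown here bears on this result.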